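Adding a Third Methoxy Group to a Benzothiazole Amide

The source may hold more compounds than are shown below. What is called first, only, known or untested is meant among the compounds shown, and "the series" means these compounds.

Compound 1 `COc1ccc(-c2cc(C(=O)Nc3nc4ccc(Cl)cc4s3)nc3cc(-c4ccccc4)nn23)cc1` was tested in a functional assay on HeLa cells (Homo sapiens) for cytotoxicity, read by MTT assay, with a stated time of 48 h (a higher number here means a weaker inhibitor, a lower number a stronger inhibitor), where compound 1 gave 5880 nM. Compound 2 `COc1ccc(-c2cc(C(=O)Nc3nc4ccc(Cl)cc4s3)nc3cc(-c4ccccc4)nn23)cc1OC` differs from it by methoxy in place of hydrogen on an aromatic carbon; in this assay compound 2 gave 9120 nM, which was a 1.6-fold higher number from compound 1 to compound 2 (0.19 log units; within the scatter). Compound 3 `COc1ccc(-c2cc(C(=O)Nc3nc4cc(C)c(C)cc4s3)nc3cc(-c4ccccc4)nn23)cc1OC` carries a different group on the amide-type nitrogen, and in this assay compound 3 gave 6760 nM, which was a 1.3-fold lower number from compound 2 to compound 3 (0.13 log units; within the scatter). The difference between the cores of compound 1 and compound 3 is not broken down here.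

Compound 4 `COc1cc(-c2cc(C(=O)Nc3nc4cc(C)c(C)cc4s3)nc3cc(-c4ccccc4)nn23)cc(OC)c1OC` has not yet been measured. It differs from compound 3 by methoxy in place of hydrogen on an aromatic carbon. This is the same kind of change as that made from compound 1 to compound 2, though not the same: in compound 4 the entering group also sits meta to a methoxy group, which was not the case in compound 2. Since the earlier step of a 1.6-fold higher number from compound 1 to compound 2 (0.19 log units; within the scatter) stayed within the scatter, a step of similar size is expected here, namely a 1.5-fold higher number from compound 3 to compound 4 (0.17 log units; within the scatter). Compound 4 is therefore estimated at 10000 nM, with a range from 4500 nM to 22000 nM.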

Compound 4, half-maximal inhibitory concentration: 8910 nM
Estimate against measurement, compound 4: 1.1-fold (0.05 log units) above; low and high end bracket the measured number.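

In this assay, adding the methoxy group to the core of compound 3 gave a 1.3-fold higher number from compound 3 to compound 4 (0.12 log units; within the scatter), so the change from 3,4-dimethoxyphenyl to 3,4,5-trimethoxyphenyl stayed within the scatter, as the earlier methoxy step did on the core of compound 1. Set side by side, the two steps show no detectable difference in how this change behaves on the two cores: the same change on two cores in this assay, a 1.6-fold higher number (0.19 log units; within the scatter) from compound 1 to compound 2 and a 1.3-fold higher number (0.12 log units; within the scatter) from compound 3 to compound 4, 1.2-fold (0.07 log units) apart, within the scatter of two such steps. This does not show that the methoxy group has any effect of its own in this assay, and a single pair of cores gives no rule for other cores in the series.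

The compounds shown leave open whether a different group in place of a methoxy group on the 3,4,5-trimethoxyphenyl ring, such as a hydroxyl, an amine or a carboxylic acid, would give a step beyond the scatter. They also leave open how an open-chain alkyl group would compare with the 5,6-dimethyl-1,3-benzothiazol-2-yl group on the amide nitrogen.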